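The source may report more compounds than this note shows. Statements on the series, on what has been measured and on what is new or still open speak of the compounds shown alone.

Of the compounds shown here, three sharing one core have been tested, differing only in the group on an oxygen on an aromatic ring. Compound 1 `CCOc1ccc2oc(/C=C/[S+](C)[O-])cc(=O)c2c1` carries an ethyl there; in a functional assay on A549 cells (Homo sapiens) for cytotoxicity, with a stated time of 48 h (on this read-out higher numbers stand for weaker inhibition and lower numbers for stronger inhibition), compound 1 gives 1500 nM. Compound 2 `CC(C)COc1ccc2oc(/C=C/[S+](C)[O-])cc(=O)c2c1` carries an isobutyl, and in this assay compound 2 gives 1100 nM. Compound 3 `COc1ccc2oc(/C=C/[S+](C)[O-])cc(=O)c2c1` carries a methyl, and in this assay compound 3 gives 1600 nM. The three numbers sit together: a 1.4-fold lower number from compound 1 to compound 2 (0.13 log units; within the scatter), a 1.1-fold higher number from compound 1 to compound 3 (0.03 log units; within the scatter) and a 1.5-fold higher number from compound 2 to compound 3 (0.16 log units; within the scatter), so compound 3 stands level with the other two rather than apart from them.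

Compound 4 `C[S+]([O-])/C=C/c1cc(=O)c2cc(O)ccc2o1` takes the change one bond further in: hydrogen in place of methyl on an oxygen on an aromatic ring. No measured step covers this exact change, but the three steps that swap one saturated chain on that oxygen for another all stayed within the scatter, so the oxygen substituent has shown little leverage on this assay. On that basis little movement is expected, and compound 4 is estimated at 1600 nM (range 700 nM to 3600 nM), a step of no change at the digits printed from compound 3 to compound 4 (within the scatter).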

Compound 4, half-maximal inhibitory concentration: 10500 nM
The estimate for compound 4 lay 6.6-fold (0.82 log units) below the measured number; measured number above the stated range.
By their numbers in this assay, from the lowest: compounds 2, 1 and 3 (each within the scatter of the next); then compound 4.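

In this assay, the oxygen substituent matters after all, though only when the chain is removed entirely: going from methoxy to hydroxy gives a 6.6-fold higher number from compound 3 to compound 4 (0.82 log units; beyond the scatter), and the same loss of a chain gives a 7.0-fold higher number from compound 1 to compound 4 (0.85 log units; beyond the scatter) and a 9.5-fold higher number from compound 2 to compound 4 (0.98 log units; beyond the scatter). All three steps lie beyond the scatter and point to weaker inhibition, so methyl, ethyl and isobutyl behave alike here, while the hydroxy of compound 4 stands apart as the weakest of the four. Nothing measured here explains why hydrogen on this oxygen differs from a saturated chain.

The compounds shown leave open whether the shift belongs to the hydroxy alone or would also appear with other groups at this position. An acetyl on that oxygen, or an amine on the ring in place of the hydroxy, could land with the three chains or with compound 4.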